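The source may report more compounds than this note shows. Statements on the series, on what has been measured and on what is new or still open speak of the compounds shown alone.

Compound 1 `CCOC(=O)c1c(-c2cccc(OC)c2)[nH]c2cc(OC)ccc2c1=O`: > 21500 nM
Compound 2 `CCOC(=O)c1c(-c2cccc(OC(F)(F)F)c2)[nH]c2cc(OC)ccc2c1=O`: > 21500 nM
Compound 3 `CCOC(=O)c1c(-c2cccc(C(F)(F)F)c2)[nH]c2cc(OC)ccc2c1=O`: > 21500 nM

All three entries are limits in an ADME assay on HepG2 cells (Homo sapiens) for cytotoxicity, read by luminescence, with a stated time of 72 h (on this read-out higher numbers stand for an effect only at larger amounts of compound and lower numbers for an effect already at smaller amounts), not numbers. Compound 1 therefore has no exact place in the series, and it shares the limit of > 21500 nM in this assay, at which 3 of the 3 values shown sit, with the other two. Compound 4 `CCOC(=O)c1c(-c2cccc(OC)c2)[nH]c2cc(SC)ccc2c1=O` is not yet measured. It differs from compound 1 by methylsulfanyl in place of methoxy on an aromatic carbon, with methylsulfanyl in place of methoxy on an aromatic carbon. The measured changes are a step that the two limits leave unreadable from compound 1 to compound 2, a step that the two limits leave unreadable from compound 1 to compound 3 and a step that the two limits leave unreadable from compound 2 to compound 3. None of them is this exchange, and none gives a size. Compound 1 anchors the expectation, and its > 21500 nM is a limit. The estimated step, a step that the limit leaves unreadable from compound 1 to compound 4, is expected to stay within the scatter. For compound 4 the estimate is 25000 nM, with an expected range of 10000 nM to 50000 nM.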

Compound 4, half-maximal effective concentration: > 21500 nM
Compound 4 was reported as a limit; the forecaster's own chance of this, stated with the estimate: 75%; the middle value does not contradict the limit.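

Compound 1 and compound 4 both stand as limits, so no step between them can be read: the limit of > 21500 nM in this assay, at which 4 of the 4 values shown sit.

The compounds shown leave open whether any change to the shared core gives a measurable value in this assay.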